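Phenyl for Benzyl on an Amide Nitrogen

This account rests on a few compounds, and the source may have more. Where it says the series, first, only, none or still open, it means among the compounds named here.

Compound 1, `COc1cccc(OC)c1C(=O)Nc1c[nH]nc1C(=O)NC1CC1`: in an ADME assay on MRC5 cells (Homo sapiens) for inhibition, with a stated time of 72 h (on this read-out higher numbers stand for an effect only at larger amounts of compound and lower numbers for an effect already at smaller amounts), compound 1 gives > 50000 nM, a limit of the assay.
Compound 2, `COCCNC(=O)c1n[nH]cc1NC(=O)c1c(OC)cccc1OC`: compound 2 gives > 50000 nM, a limit of the assay.
Compound 3, `COc1cccc(OC)c1C(=O)Nc1c[nH]nc1C(=O)NCc1ccccc1`: compound 3 gives 50000 nM.

Compound 3 stands alone in giving a number; the other two values are only limits, as the limit of > 50000 nM in this assay, at which 2 of the 3 values shown sit, states. Compound 4, `COc1cccc(OC)c1C(=O)Nc1c[nH]nc1C(=O)Nc1ccccc1`, differs from compound 3 in one place: phenyl in place of benzyl on an amide-type nitrogen. Two measured steps lead to compound 3, a number no higher from compound 1 to compound 3 (the limit leaves the size open) and a number no higher from compound 2 to compound 3 (the limit leaves the size open), and neither has a readable size. The remaining step, a step that the two limits leave unreadable from compound 1 to compound 2, is unreadable for the same reason. So nothing measured puts a size on a change of this kind, and no step beyond the usual scatter is expected in either direction. Compound 4 is therefore expected to give 50000 nM, with a range from 25000 nM to 100000 nM, and a limit rather than a number is the more likely outcome. The expected step is no change at the digits printed from compound 3 to compound 4 (within the scatter).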

Compound 4, half-maximal effective concentration: > 50000 nM
Compound 4: no number, only a limit; the forecaster's own chance of this, stated with the estimate: 70%; the middle value lies on the limit itself.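

In this assay, phenyl in place of benzyl on the amide-type nitrogen gives a number no lower from compound 3 to compound 4 (the limit leaves the size open). Compound 4 keeps a six-membered aromatic ring on that nitrogen, yet compound 3 remains the only one of the four with a number, so in this pair the ring alone does not bring a value inside the range of the assay. The size of the step stays unknown, and the steps to compound 4 from compound 1 and compound 2 cannot be read at all, because the values sit at the edge of what the assay reports: the limit of > 50000 nM in this assay, at which 3 of the 4 values shown sit.

As far as these compounds go, what a longer chain such as 2-phenylethyl would do on this nitrogen remains open. So does the effect of an amine or a carboxylic acid on the phenyl ring.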